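Working notes: changing the group on the carbonyl carbon

A few compounds are considered here, and "the series" means these few. Any claim that something is new, unique, unknown or untested is made for them only; others in the source may bear on it.

Measured compounds in a functional assay on MCF7 cells (Homo sapiens) for cytotoxicity, read by MTT assay, with a stated time of 48 h; on this read-out higher numbers stand for weaker inhibition and lower numbers for stronger inhibition:
compound 1, `COc1cc(-c2nnc3n2NC(c2cccs2)C(C(=O)c2ccc(C)cc2)S3)cc(OC)c1OC`, gives 28400 nM.
compound 2, `COc1ccc(C(=O)C2Sc3nnc(-c4cc(OC)c(OC)c(OC)c4)n3NC2c2ccco2)cc1`, gives > 100000 nM, which is a limit of the assay and not a number.
compound 3, `COc1cc(-c2nnc3n2NC(c2ccco2)C(C(=O)c2ccccc2F)S3)cc(OC)c1OC`, gives 94800 nM.

Compound 2 stands at the limit of this assay; of the three values shown, one sits there (the limit of > 100000 nM in this assay, at which 1 of the 3 values shown sits), so only a bound is known for compound 2. Compound 3 returns a number, and the step of an at least 1.0-fold lower number from compound 2 to compound 3 (0.02 log units; that floor lies within the scatter) stays within the scatter, so the change from 4-methoxyphenyl to 2-fluorophenyl on the carbonyl carbon moved nothing that can be read. For the measured compounds named here, compound 1 differs from compound 2 in more than one place; its values show a lower number, but no single-change step joins it to compound 2 or compound 4.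

Compound 4, `COc1cc(-c2nnc3n2NC(c2ccco2)C(C(=O)c2ccccc2C)S3)cc(OC)c1OC`, is not yet measured. Its change from compound 2 is 2-methylphenyl in place of 4-methoxyphenyl on a carbonyl carbon. Going by the values given here, the only measured step that bears on it is the one from compound 2 to compound 3, where the same 4-methoxyphenyl was replaced and the number did not move beyond the scatter. The same outcome is therefore expected here: a step of a number no higher from compound 2 to compound 4 (the limit leaves the size open), that is, none beyond the scatter. For compound 4 in this assay the estimate is 100000 nM, expected to fall between 40000 nM and 300000 nM, with a fair chance that only a limit is reported.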

Compound 4, half-maximal inhibitory concentration: 69900 nM
Compound 4: the middle estimate sits 1.4-fold (0.16 log units) above what was measured; the measured number falls inside the stated range.
By their numbers in this assay, from the lowest: compound 1; then compounds 4 and 3 (each within the scatter of the next). At a limit, above all of these: compound 2.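

In this assay, 2-methylphenyl in place of 4-methoxyphenyl on the carbonyl carbon gives an at least 1.4-fold lower number from compound 2 to compound 4 (0.15 log units; that floor lies within the scatter), so a second replacement at this position, this one with no hydrogen-bond acceptor, also moves nothing that can be read. For the compounds shown here, the first comparison between two actual numbers at this position is a 1.4-fold lower number from compound 3 to compound 4 (0.13 log units; within the scatter), so methyl and fluoro on the aromatic carbon cannot be told apart here. Compound 2 remains a limit of the assay and not a number, so the true size of its steps stays unknown: the limit of > 100000 nM in this assay, at which 1 of the 4 values shown sits.

Still open, as far as these compounds go, is whether an amine or a carboxylic acid on the phenyl group, or a longer chain in its place on the carbonyl carbon, would take the number beyond the scatter. Going by these compounds alone, no single-change step joins compound 1, at 28400 nM, to the other compounds, so the source of that value cannot be read.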